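Phenyl for methyl on a sulfonamide nitrogen

The compounds below may be only part of what the source reports. "The series", "measured", "known", "first", "only" and "open" are said of these compounds alone.

In a functional assay on PC-3 cells (Mus musculus) for cytotoxicity against PC-3 (Homo sapiens) (a higher number here means a weaker inhibitor, a lower number a stronger inhibitor), compound 1 (`CCCN(CCC)c1c([N+](=O)[O-])cc(S(=O)(=O)Nc2cccc(OC)c2)cc1[N+](=O)[O-]`) gives 36000 nM and compound 2 (`CCCN(CCC)c1c([N+](=O)[O-])cc(S(=O)(=O)Nc2cccc(C)c2)cc1[N+](=O)[O-]`) gives 25000 nM as measured numbers. Compound 3 (`CCCN(CCC)c1c([N+](=O)[O-])cc(S(=O)(=O)N(C)c2ccccc2)cc1[N+](=O)[O-]`) shows > 100000 nM as a limit, not a number. Compound 4 (`CCCN(CCC)c1c([N+](=O)[O-])cc(S(=O)(=O)N(c2ccccc2)c2ccccc2)cc1[N+](=O)[O-]`), not yet measured, has phenyl in place of methyl on a sulfonamide nitrogen is the full change. For the measured compounds named here, no measured step makes this exact swap. The nearest guides are an at least 2.7-fold higher number from compound 1 to compound 3 (0.44 log units; beyond the scatter) and an at least 4.0-fold higher number from compound 2 to compound 3 (0.60 log units; beyond the scatter) and both point upward, so no return to lower numbers is expected, and no step beyond the scatter in this assay either. The expected step is a number no higher from compound 3 to compound 4 (the limit leaves the size open) in size. Compound 4 is estimated at 100000 nM with a range from 35000 nM to 250000 nM for now.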

Compound 4, half-maximal inhibitory concentration: > 100000 nM
Compound 4: no number, only a limit; the forecaster's own chance of this, stated with the estimate: 65%; the middle value sits exactly at the limit.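

Compound 3 and compound 4 both give a limit rather than a number, so no step can be read between them: the limit of > 100000 nM in this assay, at which 2 of the 4 values shown sit. The compounds shown leave open whether phenyl in place of methyl on a sulfonamide nitrogen changes the number at all.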